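Paw edema series: compound 1 to compound 4

The source may hold more compounds than are shown below. What is called first, only, known or untested is meant among the compounds shown, and "the series" means these compounds.

Compound 1 `O=C(N/N=C/c1ccccc1)c1cccnc1Nc1cccc(C(F)(F)F)c1` carries the shared core with an unsubstituted phenyl on the carbon double-bonded to nitrogen. Within the data shown here, in a functional assay on the whole organism (strain Wistar) for inhibition, with Rattus norvegicus as the target, read by paw edema, with a stated time of 3 h, at a dose of 10 mg/kg by the intraperitoneal route (a lower number here means less inhibition, a higher number more inhibition at the dose given (going by the name of the read-out)), compound 1 gives 21.2%, the lowest of the three numbers so far. Compound 2 `O=C(N/N=C/c1ccc(O)c(O)c1)c1cccnc1Nc1cccc(C(F)(F)F)c1` gives 38.2%, and compound 3 `COc1cccc(/C=N/NC(=O)c2cccnc2Nc2cccc(C(F)(F)F)c2)c1` gives 30.3%. The steps from compound 1 are a number 17 percentage points higher from compound 1 to compound 2 (beyond the scatter) and a number 9.1 percentage points higher from compound 1 to compound 3 (within the scatter); between the two substituted analogues the step is a number 7.9 percentage points lower from compound 2 to compound 3 (within the scatter).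

Compound 4 `COc1ccc(/C=N/NC(=O)c2cccnc2Nc2cccc(C(F)(F)F)c2)cc1OC` is the unmeasured member. Its change from compound 1 is 3,4-dimethoxyphenyl in place of phenyl on a carbon with a double bond to nitrogen. Among the measured compounds shown here, both earlier steps out of compound 1 bear on this one: the 3,4-dihydroxyphenyl step was beyond the scatter, the single methoxy step within it. A 3,4-dimethoxyphenyl is expected to land between those two outcomes, so a modest rise is expected, a number 11.8 percentage points higher from compound 1 to compound 4 (beyond the scatter), which may or may not clear the scatter. The estimate for compound 4 in this assay is 33%, with a range from 22% to 44%.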

Compound 4, a percentage reported as inhibition, in the whole organism at one dose (the size of the read-out at that dose, not a potency): 44%
Compound 4: middle estimate off by 11 percentage points, on the low side, and the stated range covers the measured number.
By their numbers in this assay, from the lowest: compounds 1, 3, 2 and 4 (each within the scatter of the next, the first and the last beyond it).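

Against phenyl, 3,4-dimethoxyphenyl on the carbon with a double bond to nitrogen gives a rise beyond the scatter in this assay (a number 22.8 percentage points higher from compound 1 to compound 4 (beyond the scatter)), and adding a further methoxy in place of hydrogen on an aromatic carbon also counts here (a number 13.7 percentage points higher from compound 3 to compound 4 (beyond the scatter)), although the single methoxy step out of compound 1 stayed within the scatter. Free hydroxyl groups are not required for a rise at this position, since 3,4-dimethoxyphenyl and 3,4-dihydroxyphenyl cannot be told apart (a number 5.8 percentage points higher from compound 2 to compound 4 (within the scatter)). No measurement on hand accounts for these differences.

Open, as far as these compounds go, is whether a longer chain such as ethoxy on the phenyl would hold the rise. Equally open, from the compounds shown here alone, is how an amine or a carboxylic acid on that ring would read at this single dose.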